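From a Methylphenyl to an Acetamidophenyl Group

The compounds below may be only part of what the source reports. "The series", "measured", "known", "first", "only" and "open" are said of these compounds alone.

Three compounds share one core and differ only in the group attached to an aromatic nitrogen. Compound 1 `N#CC1=C(N)Oc2c(c3nc4ccccc4nc3c3ccccc23)C12C(=O)N(Cc1cnnn1-c1ccc(Br)cc1)c1ccccc12` was tested in an ADME assay on HUVEC cells (Homo sapiens) for antiproliferative activity, read by MTT assay, with a stated time of 48 h; on this read-out lower numbers stand for stronger inhibition and higher numbers for weaker inhibition. In this assay compound 1 gives > 50000 nM, which is a limit of the assay rather than a number. Compound 2 `N#CC1=C(N)Oc2c(c3nc4ccccc4nc3c3ccccc23)C12C(=O)N(Cc1cnnn1-c1cccc(Br)c1)c1ccccc12` gives in this assay > 50000 nM, again only a limit. The step that the two limits leave unreadable from compound 1 to compound 2 therefore cannot be read. Compound 3 `Cc1ccccc1-n1nncc1CN1C(=O)C2(C(C#N)=C(N)Oc3c(N)cc4nc5ccccc5nc4c32)c2ccccc21` gives in this assay > 50000 nM, once more a limit. Among the compounds with values here, all three measured values thus sit at the limit of > 50000 nM in this assay, at which 3 of the 3 values shown sit, so no compound can be ranked against another.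

Compound 4 `CC(=O)Nc1ccc(-n2nncc2CN2C(=O)C3(C(C#N)=C(N)Oc4c(N)cc5nc6ccccc6nc5c43)c3ccccc32)cc1` has not yet been measured. It differs from compound 3 in one place: 4-acetamidophenyl in place of 2-methylphenyl on an aromatic nitrogen. Within the data shown here, no measured step bears on this change: the only measured step concerns a bromophenyl group and its size is unreadable. With three limits and no readable step, no direction can be derived from the numbers shown, and the plainest expectation is that compound 4 also stays at the limit. The expected step is a number no higher from compound 3 to compound 4 (the limit leaves the size open). Compound 4 is expected to give 50000 nM in this assay, with a range from 15000 nM to 100000 nM.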

Compound 4, half-maximal inhibitory concentration: > 50000 nM
Compound 4: only a limit was reported; the forecaster's own chance of this, stated with the estimate: 80%; the middle value lies on the limit itself.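

Compound 3 and compound 4 are both reported only as limits in this assay, so the step between them cannot be read, and all the values shown now stand at one limit: the limit of > 50000 nM in this assay, at which 4 of the 4 values shown sit. The compounds shown leave open whether changing the group on the aromatic nitrogen alters the result in this assay at all.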